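Changing the Sulfonyl Aryl Group of a Urea Inhibitor

The source may hold more compounds than are shown below. What is called first, only, known or untested is meant among the compounds shown, and "the series" means these compounds.

Compound 1, `O=C(NCc1ccc(S(=O)(=O)c2ccccc2)cc1)NCc1cccnc1`: 19 nM
Compound 2, `O=C(NCc1ccc(S(=O)(=O)c2ccccc2)cc1)N1CCc2ccncc2C1`: 310 nM
Compound 3, `O=C(NCc1ccc(S(=O)(=O)c2cncc(C(F)(F)F)c2)cc1)N1Cc2ccncc2C1`: 15 nM

In an assay on isolated protein for inhibition of Nicotinamide phosphoribosyltransferase (Homo sapiens), read by mass spectrometry, with stated times of 15 min and 30 min (a higher number here means a weaker inhibitor, a lower number a stronger inhibitor), compound 3 gives the lowest of the three numbers, though compound 1 lies within the scatter of it; only compound 2 stands beyond the scatter, above it. Compound 4, `CC(C)n1cc(S(=O)(=O)c2ccc(CNC(=O)N3Cc4ccncc4C3)cc2)cn1`, differs from compound 3 by 1-isopropyl-1H-pyrazol-4-yl in place of 5-(trifluoromethyl)pyridin-3-yl on a sulfonyl sulfur. For the measured compounds named here, no measured pair shows this change, so its size is not known from the data. Compound 1 and compound 3 sit close together despite different sulfonyl aryl groups, so the step is expected to be small, with the estimated step of a 1.7-fold higher number from compound 3 to compound 4 (0.22 log units; within the scatter) leaning slightly weaker. Compound 4 is expected to give about 25 nM, within a range from 8 nM to 80 nM.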

Compound 4, half-maximal inhibitory concentration: 20 nM
For compound 4 the middle estimate is 1.3-fold (0.10 log units) above the measured one; measured number inside the range.
By their numbers in this assay, from the lowest: compounds 3, 1 and 4 (each within the scatter of the next); then compound 2.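

In this assay, 1-isopropyl-1H-pyrazol-4-yl in place of 5-(trifluoromethyl)pyridin-3-yl on a sulfonyl sulfur gives a 1.3-fold higher number from compound 3 to compound 4 (0.12 log units; within the scatter), the first step measured at this position. It shows that a five-membered aromatic ring with 2 hetero atoms can replace a six-membered aromatic ring with 1 hetero atom there without a shift beyond the scatter. No measurement shown accounts for this result. The compounds shown leave open whether a saturated ring such as cyclohexyl or piperidine would fare the same at this position. They also leave open the effect of a carboxylic acid or an amine on the pyrazole.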